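The source may hold more compounds than are shown below. What is called first, only, known or untested is meant among the compounds shown, and "the series" means these compounds.

Working notes on the series. Compound 1 `COc1ccc(C(=O)C2Sc3nnc(-c4cc(OC)c(OC)c(OC)c4)n3NC2c2ccco2)cc1` is the reference point. In a functional assay on HepG2 cells (Homo sapiens) for cytotoxicity, read by MTT assay, with a stated time of 48 h (on this read-out lower numbers stand for stronger inhibition and higher numbers for weaker inhibition), compound 1 gives > 100000 nM; this is a limit of the assay and not a number, so compound 1 stands at the limit of > 100000 nM in this assay, at which 1 of the 2 values shown sits. Compound 2 `COc1cc(-c2nnc3n2NC(c2cccs2)C(C(=O)c2ccc(Cl)cc2)S3)cc(OC)c1OC` is the other member with a result: in this assay compound 2 gives 13200 nM. Within the data shown here, compound 2 differs from compound 1 in more than one place, so these two values show only that one sits at the limit while the other is a number; no single step between them can be drawn.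

Compound 3 `COc1cc(-c2nnc3n2NC(c2ccco2)C(C(=O)c2ccc(-c4ccccc4)cc2)S3)cc(OC)c1OC` has not yet been measured. Its difference from compound 1 is phenyl in place of methoxy on an aromatic carbon. With compound 1 at a limit there is no measured anchor for the size of this step. Compound 3 is expected to move by an at least 2.5-fold lower number from compound 1 to compound 3 (0.39 log units; beyond the scatter), in the direction of stronger inhibition, with a real chance that the assay again returns only a limit. The estimate for compound 3 in this assay is 40000 nM, with a range from 8000 nM to 200000 nM.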

Compound 3, half-maximal inhibitory concentration: > 100000 nM
Compound 3 was reported as a limit; the forecaster's own chance of this, stated with the estimate: 50%; at least 2.5-fold (0.39 log units) between middle value and limit.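

In this assay compound 3 gives > 100000 nM which is a limit of the assay and not a number. Among these compounds, compound 1 also stands at a limit, so no step between compound 1 and compound 3 can be read. The compounds shown leave open whether phenyl in place of methoxy shifts the read-out at all.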